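Working notes: from compound 1 to compound 4

This account rests on a few compounds, and the source may have more. Where it says the series, first, only, none or still open, it means among the compounds named here.

compound 1, `COc1cc(-c2cc(/C=C/C(=O)c3ccc(N)cc3)[nH]n2)cc(OC)c1OC`: 94%
compound 2, `COc1ccc(-c2cc(/C=C/C(=O)c3ccc(N)cc3)[nH]n2)cc1`: 95%
compound 3, `COc1cc(C(=O)/C=C/c2cc(-c3cc(OC)c(OC)c(OC)c3)n[nH]2)cc(OC)c1OC`: 104%

All three numbers come from a functional assay on K562 cells (Homo sapiens) for cytotoxicity, read by sulforhodamine B assay, with a stated time of 48 h, tested at 0.1 uM; on this read-out lower numbers stand for a stronger effect and higher numbers for a weaker effect at the one concentration tested. Compound 1 carries the lowest number of the three, yet compound 2 and compound 3 both lie within the scatter of it, so no order among the three can be read, and none of them shows a marked effect at the concentration tested.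

Compound 4, `COc1cc(-c2cc(/C=C/C(=O)c3ccc(F)c(F)c3)[nH]n2)cc(OC)c1OC`, is not yet measured. It differs from compound 1 in one place: 3,4-difluorophenyl in place of 4-aminophenyl on a carbonyl carbon. Going by the values given here, no step between measured compounds bears on this change. With compound 1 at 94% and compound 3 at 104%, the measured numbers sit close together near the top of the scale.

In this assay the expected step of a number 2 percentage points higher from compound 1 to compound 4 (within the scatter) is no larger than the scatter, with no set direction. Compound 4 is estimated at 96%, with a range from 82% to 108%.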

Compound 4, a percentage reported as activity, at one concentration (the size of the read-out at that concentration, not a potency): 109%
Estimate against measurement, compound 4: 13 percentage points below; the whole stated range lies below it.
By their numbers in this assay, from the lowest: compounds 1, 2, 3 and 4 (each within the scatter of the next, the first and the last beyond it).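

In this assay, going by these compounds alone, the change to 3,4-difluorophenyl in place of 4-aminophenyl on a carbonyl carbon gives the only step that lies beyond the scatter: a number 15 percentage points higher from compound 1 to compound 4 (beyond the scatter). The group on this carbonyl carbon can therefore shift the read-out, though only modestly at the one concentration tested. Nothing at hand accounts for this step.

The compounds shown leave open whether the step follows from losing the 4-aminophenyl or from adding the fluorines. Plain phenyl or 4-hydroxyphenyl on the same carbonyl carbon would bear on that question.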